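Ring-carbon alkyl swap in a bis-aziridinyl quinone-type series

The compounds below may be only part of what the source reports. "The series", "measured", "known", "first", "only" and "open" are said of these compounds alone.

Notes on a small set sharing one core. Compound 1 `CCCC1=C(N2CC2)C(=O)C(CCC)=C(N2CC2)C1=O` carries propyl groups on the core; compound 3 `CCC1=C(N2CC2)C(=O)C(CC)=C(N2CC2)C1=O` carries ethyl groups; compound 2 `CC(C)C1=C(N2CC2)C(=O)C(C(C)C)=C(N2CC2)C1=O` carries isopropyl groups. In a functional assay with Nucleic Acid as the target, tested at 100 uM (a lower number here means a weaker effect, a higher number a stronger effect of the compound at the concentration tested), compound 1 gives 95.6% and compound 3 gives 100%, two numbers that lie within the usual scatter of each other, so no order between them is claimed. In this assay compound 2 gives 0%, the lowest of the three numbers, separated from compound 1 and from compound 3 by gaps beyond the scatter. Across three compounds, then, the smaller straight chains go with a full read-out and the branched pair with none; no further members test that pattern.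

Compound 4 `CC1=C(N2CC2)C(=O)C(C(C)C)=C(N2CC2)C1=O` has not been measured in this assay. It differs from compound 2 by a single change: methyl in place of isopropyl on a double-bonded ring carbon. One of the two groups that set compound 2 apart from compound 1 and compound 3 is thus replaced by the smallest chain of all, while the other isopropyl stays.

Going by the values given here, no step between measured compounds matches this exact change. On the numbers shown, a step upward from compound 2 is expected, probably beyond the scatter, estimated as a number 55 percentage points higher from compound 2 to compound 4 (beyond the scatter), since compound 2 sits at 0% while the straight-chain pair sits near the top of the scale. The retained isopropyl leaves the outcome uncertain. For compound 4 in this assay the expected value is 55%, with a range from 5% to 100%.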

Compound 4, a percentage reported as activity, at one concentration (the size of the read-out at that concentration, not a potency): 87.8%
Estimate against measurement, compound 4: 32.8 percentage points below; measured number inside the range.
By their numbers in this assay, from the lowest: compound 2; then compounds 4, 1 and 3 (each within the scatter of the next, the first and the last beyond it).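

In this assay, going by these compounds alone, methyl in place of isopropyl on a double-bonded ring carbon gives a number 87.8 percentage points higher from compound 2 to compound 4 (beyond the scatter), the first change that can be read at a single place. The low read-out of compound 2 therefore does not follow from the mere presence of an isopropyl group: compound 4 keeps one isopropyl group, three ring bonds from the changed atom, and still gives 87.8% at the concentration tested, so one exchange at this position is enough to lift the read-out across nearly the whole scale. Nothing measured here bears on why a change of this kind has so large an effect.

Still open, on these data alone, is whether ethyl or a longer chain such as butyl at this position, with the other isopropyl kept, would hold the read-out of compound 4 or lose it, and so where along the chains the fall begins. Also open, as far as these compounds go, is how an amine or a carboxylic acid on this ring carbon would read, and whether a read-out taken at one concentration conceals differences in potency among the compounds near the top of the scale.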